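This account rests on a few compounds, and the source may have more. Where it says the series, first, only, none or still open, it means among the compounds named here.

Of the compounds shown here, three sharing one core have been tested in a functional assay on DLA cells (Mus musculus) for cytotoxicity, read by LDH release, with a stated time of 48 h; on this read-out higher numbers stand for weaker inhibition and lower numbers for stronger inhibition: compound 1 `COc1ccc(C(=O)c2cc(C)ccc2OCC(=O)NNC(=O)c2cc3ccccc3oc2=O)cc1` gives 43400 nM, compound 2 `Cc1ccc(OCC(=O)NNC(=O)c2cc3ccccc3oc2=O)c(C(=O)c2ccccc2)c1` gives 87000 nM, and compound 3 `Cc1ccc(OCC(=O)NNC(=O)c2cc3ccccc3oc2=O)c(C(=O)c2ccc(Cl)cc2)c1` gives 60400 nM. Compound 3 stands within the scatter of both others, as a 1.4-fold higher number from compound 1 to compound 3 (0.14 log units; within the scatter) and a 1.4-fold lower number from compound 2 to compound 3 (0.16 log units; within the scatter) show, so these numbers set no firm ranking.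

The next compound, compound 4 `Cc1ccc(C(=O)c2cc(C)ccc2OCC(=O)NNC(=O)c2cc3ccccc3oc2=O)cc1`, differs from compound 3 by one small swap: methyl in place of chloro on an aromatic carbon, para to a large group (methyl in place of chloro on an aromatic carbon). Put another way, 4-chlorophenyl becomes 4-methylphenyl. Within the data shown here, no measured pair makes this exact swap, so the evidence is indirect. The closest guide is what other swaps at the same place have done. Besides the two steps already given, there is a 2.0-fold higher number from compound 1 to compound 2 (0.30 log units; within the scatter). All three steps stay within the scatter, so among these three compounds no change at this place has yet moved the number measurably. A step beyond the scatter is therefore not expected in this assay for this swap either. The estimated step is a 1.1-fold lower number from compound 3 to compound 4 (0.04 log units; within the scatter). Compound 4 is expected to give about 55000 nM, with an estimated range of 30000 nM to 100000 nM.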

Compound 4, half-maximal inhibitory concentration: 87200 nM
Beside the measured number, compound 4's estimate is 1.6-fold (0.20 log units) below it; the range from low to high includes it.
By their numbers in this assay, from the lowest: compounds 1, 3, 2 and 4 (each within the scatter of the next).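

In this assay, methyl is a fourth group tried at this place, on the aromatic carbon para to a large group, and it too produces no measurable shift: a 1.4-fold higher number from compound 3 to compound 4 (0.16 log units; within the scatter), a 1.0-fold higher number from compound 2 to compound 4 (0.00 log units; within the scatter), and a 2.0-fold higher number from compound 1 to compound 4 (0.30 log units; within the scatter). The earlier compounds shown here covered only hydrogen, methoxy and chloro, so this result extends the picture to a simple carbon group, and all four groups now lie within the scatter of one another, which means that this set gives no ranking among them and shows no measurable dependence on the group at this place. Nothing available here gives any measured property that bears on this result, so the data offer no explanation for it.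

Still open, going by these compounds, is whether a group of a different kind at this place, such as an amine, a carboxylic acid or a longer chain like butyl, would move the number beyond the scatter. The rest of the shared core is the same in all four compounds, so they also leave open how a change anywhere else in the molecule would affect this read-out.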